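The source may report more compounds than this note shows. Statements on the series, on what has been measured and on what is new or still open speak of the compounds shown alone.

In an ADME assay on NIH3T3 cells (Mus musculus) for cytotoxicity, read by MTT assay, with a stated time of 24 h (on this read-out lower numbers stand for stronger inhibition and higher numbers for weaker inhibition), compound 2 `O=C(CSc1nnc(-c2ccncc2)o1)N/N=C/c1cc(Br)ccc1O` gives 156000 nM. For the measured compounds named here, on the numbers so far it sits beside compound 1 `O=C(CSc1nnc(-c2ccncc2)o1)N/N=C/c1ccc(Cl)cc1`, which in this assay gives 181000 nM; the only step between them, a 1.2-fold lower number from compound 1 to compound 2 (0.06 log units; within the scatter), stays within the scatter. Compound 3 `O=C(CSc1nnc(-c2ccncc2)o1)N/N=C/c1ccc(O)c(O)c1` is the next step: 3,4-dihydroxyphenyl in place of 5-bromo-2-hydroxyphenyl on a carbon with a double bond to nitrogen. Going by the values given here, the one measured step bears on it only loosely, since it swaps a different aryl group, and it was small. No step beyond the scatter is therefore expected in this assay. Compound 3 is estimated at 150000 nM, between 60000 nM and 400000 nM, an expected step of a 1.0-fold lower number from compound 2 to compound 3 (0.02 log units; within the scatter).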

Compound 3, half-maximal inhibitory concentration: 154000 nM
For compound 3 the middle estimate is 1.0-fold (0.01 log units) below the measured one; the range from low to high includes it.
By their numbers in this assay, from the lowest: compounds 3, 2 and 1 (each within the scatter of the next).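

In this assay, 3,4-dihydroxyphenyl on this carbon with a double bond to nitrogen leaves the series within the scatter, both against 5-bromo-2-hydroxyphenyl (a 1.0-fold lower number from compound 2 to compound 3 (0.01 log units; within the scatter)) and against 4-chlorophenyl (a 1.2-fold lower number from compound 1 to compound 3 (0.07 log units; within the scatter)). Three different aryl groups now give numbers within the scatter of one another, and losing the bromine for a second oxygen brings no step beyond it. Nothing available explains this flat result.

On these data alone, whether an amine, a carboxylic acid or a longer chain in place of the aryl group would give a step beyond the scatter remains open.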